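This account rests on a few compounds, and the source may have more. Where it says the series, first, only, none or still open, it means among the compounds named here.

Measured in a toxicity assay on HepG2 2.2.15 cells (Homo sapiens) for cytotoxicity, read by CellTiter-Glo; a higher number here means that more compound is tolerated, a lower number that less compound is tolerated:
- Compound 1 `O=C1CC(Oc2ncccn2)CN1c1cnn2c1CN(C(=O)Nc1cc(F)c(F)c(F)c1)C(C1CC1)C2`: > 200000 nM, a limit
- Compound 2 `N#CC1CC(=O)N(c2cnn3c2CN(C(=O)Nc2cc(F)c(F)c(F)c2)C(C2CC2)C3)C1`: > 200000 nM, a limit
- Compound 3 `Cc1cnc(C2CC(=O)N(c3cnn4c3CN(C(=O)Nc3cc(F)c(F)c(F)c3)C(C3CC3)C4)C2)s1`: 96200 nM

Only compound 3 has an actual number, 96200 nM. The other two readings rest on (the limit of > 200000 nM in this assay, at which 2 of the 3 values shown sit), so compound 3 is the only one of the three with a measured value to compare against.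

Compound 4 `O=C1CC(c2ccc(F)cn2)CN1c1cnn2c1CN(C(=O)Nc1cc(F)c(F)c(F)c1)C(C1CC1)C2` keeps the rest of compound 3 but carries 5-fluoropyridin-2-yl in place of 5-methyl-1,3-thiazol-2-yl on a saturated ring carbon of the five-membered non-aromatic ring (5-fluoropyridin-2-yl in place of 5-methyl-1,3-thiazol-2-yl on a saturated ring carbon).

Going by the values given here, two measured steps bear on this position, both ending at compound 3: an at least 2.0-fold lower number from compound 1 to compound 3 (0.31 log units; beyond the scatter) and an at least 2.0-fold lower number from compound 2 to compound 3 (0.31 log units; beyond the scatter). Each starts from a limit, so each gives only a bound on the true size. The step that the two limits leave unreadable from compound 1 to compound 2 adds nothing usable.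

Among the compounds with values here, no measured step swaps one ring directly attached to that carbon for another. Compound 3, at 96200 nM, is therefore the closest guide, since compound 4 also has an aromatic ring directly on that carbon. The expected result is a 1.1-fold higher number from compound 3 to compound 4 (0.06 log units; within the scatter), with no change beyond the scatter in this assay, although a reading at the limit would be no surprise. For compound 4 the estimate is 110000 nM, with an expected range of 45000 nM to 200000 nM.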

Compound 4, half-maximal cytotoxic concentration: 38500 nM
For compound 4 the middle estimate is 2.9-fold (0.46 log units) above the measured one; measured number below the stated range.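

In this assay, going by these compounds alone, the ring attached directly to this saturated ring carbon matters, and this is the first measured swap of one such ring for another: 5-fluoropyridin-2-yl in place of 5-methyl-1,3-thiazol-2-yl gives a 2.5-fold lower number from compound 3 to compound 4 (0.40 log units; beyond the scatter), so less compound is tolerated. With the same ring entering in place of cyano the change is an at least 5.1-fold lower number from compound 2 to compound 4 (0.71 log units; beyond the scatter), and in place of (pyrimidin-2-yl)oxy it is an at least 5.1-fold lower number from compound 1 to compound 4 (0.71 log units; beyond the scatter), which widens the range of tolerated concentrations seen at this position. These last two changes are bounds rather than sizes, as each starts from a limit: the limit of > 200000 nM in this assay, at which 2 of the 4 values shown sit.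

The swap from compound 3 to compound 4 alters ring size, the hetero atoms and the substituent all at once, so the compounds shown cannot say which of these differences accounts for the lower number. Going by these compounds, it also remains open whether a plain phenyl ring, a pyridin-2-yl ring without the fluorine, or a non-aromatic group such as an amine on this carbon would give a number closer to compound 3 or compound 4.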